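Removing a Methyl from the Shared Core: Metabolic Stability

The source may report more compounds than this note shows. Statements on the series, on what has been measured and on what is new or still open speak of the compounds shown alone.

Of the compounds shown here, two built on the same core have been measured in an ADME assay on liver for metabolic stability, with Liver microsome (Rattus norvegicus) as the target, read by LC-MS, using microsomes, with a stated time of 5 h; a lower number here means slower removal, a higher number faster removal of the compound. Compound 1 `O[C@H](c1ccccn1)[C@]1(c2ccc(C(F)(F)F)cc2)C[C@@H](O)C1` gives 50 mL/min/kg in this assay. Compound 2 `C[C@]1(O)C[C@](c2ccc(C(F)(F)F)cc2)([C@H](O)c2ccccn2)C1` carries a methyl group on the saturated ring carbon that also bears the hydroxy group, and in this assay compound 2 gives 100 mL/min/kg. This is the higher of the two numbers, but the gap to compound 1 lies within the usual scatter of repeated measurements, so the two cannot be told apart with confidence.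

Compound 3 `O[C@H](c1ccccn1)[C@]1(c2ccc(C(F)(F)F)cc2)C[C@H](O)C1` is the next compound to be tested in this assay. Compared with compound 2 the change is hydrogen in place of methyl on a saturated ring carbon.

Because compound 1, which also has hydrogen at that ring carbon, gives 50 mL/min/kg, compound 3 is expected to land near that number, and the expected step of a 1.8-fold lower number from compound 2 to compound 3 (0.26 log units; within the scatter) would be a modest move toward slower removal that stays within the scatter. The estimate for compound 3 in this assay is 55 mL/min/kg, with a likely range from 25 mL/min/kg to 110 mL/min/kg.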

Compound 3, clearance: 50 mL/min/kg
Beside the measured number, compound 3's estimate is 1.1-fold (0.04 log units) above it, within the range that was stated.
By their numbers in this assay, from the lowest: compounds 1, 3 and 2 (each within the scatter of the next).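

In this assay, the swap of hydrogen for methyl on a saturated ring carbon can now be read as a single change, and it gives a 2.0-fold lower number from compound 2 to compound 3 (0.30 log units; within the scatter). On this evidence, the methyl group cannot be shown to affect clearance, as the step is no larger than the differences expected between repeat measurements of the same compound. The other pair gives no change at the digits printed from compound 1 to compound 3 (within the scatter), so the drawn configuration makes no visible difference here, a comparison that the two earlier compounds could not offer, and one that isolates configuration from any change of atoms: the fact that compounds 1 and 3 differ only in the configuration as drawn.

Still open, on these data alone, is whether a different group on that saturated ring carbon, such as an ethyl group, a fluorine atom or an amine, would shift clearance by more than the scatter. Also open, as far as these compounds go, is whether a methyl group with the configuration at that ring carbon drawn the other way would give a number close to that of compound 2, since the methyl comparison here rests on a single pair.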